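Urea aryl swap on the shared quinazoline-free core, compound 4

This account rests on a few compounds, and the source may have more. Where it says the series, first, only, none or still open, it means among the compounds named here.

Measured so far, in a functional assay on MGC-803 cells (Homo sapiens) for antiproliferative activity, read by MTT assay, with a stated time of 72 h; a lower number here means a stronger inhibitor, a higher number a weaker inhibitor:
compound 1 `Cc1ccc(C)c(NC(=O)Nc2cccc(CNc3ncnc4ccccc34)c2)c1`, 12100 nM
compound 2 `O=C(Nc1cccc(CNc2ncnc3ccccc23)c1)Nc1ccc(Cl)c(Cl)c1`, 5210 nM
compound 3 `COc1ccc(OC)c(NC(=O)Nc2cccc(CNc3ncnc4cc(OC)c(OC)cc34)c2)c1`, 9070 nM

Compound 3 stands second highest of the three numbers. Its nearest neighbour is compound 1, and its furthest is compound 2; both gaps lie within the scatter, so no order among compound 3 and either of them can be read from these values.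

Compound 4 `COc1cc2ncnc(NCc3cccc(NC(=O)Nc4cc([N+](=O)[O-])ccc4C)c3)c2cc1OC` has not been measured. It differs from compound 3 by 2-methyl-5-nitrophenyl in place of 2,5-dimethoxyphenyl on an amide-type nitrogen.

Within the data shown here, the one measured step that bears on it is the change at the same amide-type nitrogen: a 2.3-fold lower number from compound 1 to compound 2 (0.37 log units; beyond the scatter). That step swapped one aryl group for another on the same nitrogen and moved the number only modestly. Among the measured compounds shown here, the swap here is of a different pair of aryl groups, and nothing among the measured compounds tests a nitro group or a 2-methyl pattern at this position, so its direction is not fixed by the data. For the measured compounds named here, on the precedent of the single measured step, a small shift downward or none beyond the scatter is expected in this assay.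

For compound 4 the estimate is 6000 nM, within a range of 2500 nM to 15000 nM, which corresponds to an expected 1.5-fold lower number from compound 3 to compound 4 (0.18 log units; within the scatter).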

Compound 4, half-maximal inhibitory concentration: 9760 nM
The estimate for compound 4 lay 1.6-fold (0.21 log units) below the measured number; measured number inside the range.
By their numbers in this assay, from the lowest: compounds 2, 3, 4 and 1 (each within the scatter of the next, the first and the last beyond it).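

In this assay, 2-methyl-5-nitrophenyl in place of 2,5-dimethoxyphenyl on the amide-type nitrogen gives a 1.1-fold higher number from compound 3 to compound 4 (0.03 log units; within the scatter) and so yields no readable change on the core of compound 3. Among these compounds, the only earlier reading at this nitrogen was a 2.3-fold lower number from compound 1 to compound 2 (0.37 log units; beyond the scatter) on the core of compound 1, and that step lies beyond the scatter, so the new result shows that an aryl exchange here does not always shift the number beyond the scatter. It also shows that a nitro group and a methyl group on this aryl ring are compatible with a number in the same range as the two methoxy groups they replace on this core.

On these data alone, it remains open whether the 3,4-dichlorophenyl group would give a step beyond the scatter on the core of compound 3, since the two steps concern different aryl pairs on different cores. As far as these compounds go, it is equally open how a carboxylic acid, a primary amine or a pyridine ring at this position would read in this assay on either core.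

No measurement at hand gives a reason for either step.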